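Adding a Bromo Group Where Two Compounds Show Only Limits

A few compounds are considered here, and "the series" means these few. Any claim that something is new, unique, unknown or untested is made for them only; others in the source may bear on it.

Compound 1 `CCCNNC(=O)c1ccc(CNC(=O)c2cc3ccccc3o2)cc1` was tested in an assay on isolated protein for inhibition of protein deacetylase HDAC6 (Homo sapiens), read by fluorescence, with a stated time of 2 h; a higher number here means a weaker inhibitor, a lower number a stronger inhibitor. In this assay compound 1 gives > 10000 nM, which is a limit of the assay rather than a number. Compound 2 `CCCNNC(=O)c1ccc(CNC(=O)c2cc3cc(Br)ccc3[nH]2)cc1` is a related compound. In this assay compound 2 gives > 10000 nM, again a limit. Both values sit at the limit of > 10000 nM in this assay, at which 2 of the 2 values shown sit. Compound 3 `CCCNNC(=O)c1ccc(CNC(=O)c2cc3cc(Br)ccc3o2)cc1` differs from compound 1 by bromo in place of hydrogen on an aromatic carbon. Among the measured compounds shown here, no measured step shows what this change does. The step from compound 1 to compound 3 is expected to be a step that the limit leaves unreadable from compound 1 to compound 3, not beyond the scatter. Compound 3 is expected to give 15000 nM, between 5000 nM and 50000 nM, and most likely only a limit again.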

Compound 3, half-maximal inhibitory concentration: > 10000 nM
Compound 3 gave a limit, no number (the forecaster's own chance of this, stated with the estimate: 80%); the middle value does not contradict the limit.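

Among the compounds shown here, compound 1 and compound 3 both give only a limit, not a number, and no step for bromo in place of hydrogen can be read from them. The compounds shown leave open whether this bromo changes inhibition at all.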